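Exchanging a chlorophenyl for a heptyl chain beside sulfur

The compounds below may be only part of what the source reports. "The series", "measured", "known", "first", "only" and "open" are said of these compounds alone.

Measured compounds:
compound 1, `CCCCCCCCC(C)OC(=O)NC(=O)Nc1c(C(C)C)cccc1C(C)C`, 750 nM
compound 2, `CCCCCCCCCCCCC(C)(C)OC(=O)NC(=O)Oc1c(C(C)C)cccc1C(C)C`, 21 nM
compound 3, `CC(C)c1cccc(C(C)C)c1OC(=O)NC(=O)SCc1ccc(Cl)cc1`, 160 nM

All three were tested in an assay on microsomes from intestine for inhibition of acyl-CoA:cholesterol acyltransferase (Oryctolagus cuniculus); a lower number here means a stronger inhibitor, a higher number a weaker inhibitor. Compound 3 stands second highest of the three numbers, with compound 1 giving 750 nM and compound 2 giving 21 nM.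

Compound 4, `CCCCCCCCSC(=O)NC(=O)Oc1c(C(C)C)cccc1C(C)C`, has not been measured. It differs from compound 3 in one place: heptyl in place of 4-chlorophenyl on a saturated chain carbon bound to a sulfur. Among the compounds with values here, no pair of measured compounds shows this same exchange, so there is no measured step to lean on; the values of compound 1 and compound 2 only show that a long saturated chain can sit with a low number. A modest move toward a lower number is expected, a 2.0-fold lower number from compound 3 to compound 4 (0.30 log units; within the scatter), not far beyond the scatter. Compound 4 is estimated at 80 nM, with a range from 25 nM to 250 nM.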

Compound 4, half-maximal inhibitory concentration: 160 nM
The estimate for compound 4 lay 2.0-fold (0.30 log units) below the measured number, within the range that was stated.
By their numbers in this assay, from the lowest: compound 2; then compounds 3 and 4 (each within the scatter of the next); then compound 1.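

In this assay, within the data shown here, exchanging 4-chlorophenyl for heptyl on a saturated chain carbon bound to a sulfur gives no change at the digits printed from compound 3 to compound 4 (within the scatter) and so adds something the earlier compounds could not show. For this pair, the aromatic ring with its chlorine is not required to keep this level of inhibition, since an open saturated chain of 7 heavy atoms serves alike. Nothing available explains why the two groups read alike.

On these data alone, whether a butyl chain, a dodecyl chain or a group carrying an amine would read the same at this position remains open.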